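Working notes: from compound 3 to compound 4

A few compounds are considered here, and "the series" means these few. Any claim that something is new, unique, unknown or untested is made for them only; others in the source may bear on it.

Measured so far in a functional assay on MCF7 cells (Homo sapiens) for cytotoxicity, read by MTT assay, with a stated time of 68 h; a higher number here means a weaker inhibitor, a lower number a stronger inhibitor
compound 1 `O=C(/C=C/c1cccc(OCc2ccccc2)c1)c1ccc([N+](=O)[O-])cc1` gives 17500 nM
compound 2 `COc1cc([C@H]2Oc3cc([C@H]4Oc5ccccc5C(=O)[C@@H]4O)ccc3O[C@@H]2CO)ccc1O` gives 13800 nM
compound 3 `O=C(/C=C/c1cccc(OCc2ccccc2)c1)c1ccc(Cl)cc1` gives 24800 nM

In this assay compound 3 lies within the scatter of both compound 1 and compound 2, so these numbers place it in one group with them and give no order among them.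

The next compound is compound 4 `O=C(/C=C/c1cccc(OCc2ccccc2)c1)c1ccc(Cl)c(Cl)c1Cl`, which differs from compound 3 by one change: 2,3,4-trichlorophenyl in place of 4-chlorophenyl on a carbonyl carbon. In words, 2,3,4-trichlorophenyl stands in place of 4-chlorophenyl on a carbonyl carbon.

Among the compounds with values here, only one measured step bears on this change: a 1.4-fold higher number from compound 1 to compound 3 (0.15 log units; within the scatter). That step exchanges nitro for chloro on an aromatic carbon and stays within the scatter. Within the data shown here, no measured step shows what further chlorine does, so the evidence is thin and the range has to stay wide. On the strength of a 1.4-fold higher number from compound 1 to compound 3 (0.15 log units; within the scatter) and of compound 3 at 24800 nM in this assay, no shift beyond the scatter is expected, in either direction.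

The expected step is a 1.2-fold lower number from compound 3 to compound 4 (0.09 log units; within the scatter) and remains an estimate.

In this assay the estimated value for compound 4 is 20000 nM, with 8000 nM to 45000 nM as the expected range.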

Compound 4, half-maximal inhibitory concentration: 2400 nM
The estimate for compound 4 lay 8.3-fold (0.92 log units) above the measured number; measured number below the stated range.
By their numbers in this assay, from the lowest: compound 4; then compounds 2, 1 and 3 (each within the scatter of the next).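

In this assay the aryl group on the carbonyl carbon proves able to move the number beyond the scatter: 2,3,4-trichlorophenyl in place of 4-chlorophenyl gives a 10-fold lower number from compound 3 to compound 4 (1.01 log units; beyond the scatter) and the same group in place of 4-nitrophenyl gives a 7.3-fold lower number from compound 1 to compound 4 (0.86 log units; beyond the scatter) as the second reading of this change. The earlier exchange of nitro for chloro at this aryl group stayed within the scatter, so compound 1 and compound 3 alone gave no sign that this position could respond so strongly. The step therefore belongs to the change to the trichlorinated ring and not to the mere presence of a chloro group, though this rests on compound 4 alone.

The compounds shown do not separate the contributions of the further chlorines, since a dichlorophenyl group is absent from them, and they do not show whether a ring carrying bromo, dimethylamino or a carboxylic acid would follow the same course. No measurement shown here bears on why the number falls at this position.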